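The compounds below may be only part of what the source reports. "The series", "measured", "known", "first", "only" and "open" are said of these compounds alone.

Measured compounds:
Compound 1 `O=C(O)C1(Sc2ccnc3ccncc23)CCC1` gives 1930 nM in an assay on HEK293 cells for inhibition of solute carrier family 22 member 12 (Homo sapiens), read by scintillation counting, with a stated time of 12 min; a higher number here means a weaker inhibitor, a lower number a stronger inhibitor.
Compound 3 `N#CCOc1ccc2nccc(SC3(C(=O)O)CCC3)c2c1` gives 680 nM in this assay.
Compound 2 `O=C(O)C1(Sc2nccc3ncccc23)CCC1` gives only > 10000 nM in this assay, which is a limit of the assay and not a number; this is the limit of > 10000 nM in this assay, at which 1 of the 3 values shown sits.

Among the two numbers shown, compound 3 has the lowest; the nearest is compound 1, whose number is higher by a step beyond the scatter. Compound 4 `Cc1ccc2nccc(SC3(C(=O)O)CCC3)c2c1` has not yet been measured. It differs from compound 3 in one place: methyl in place of cyanomethoxy on an aromatic carbon. The shared core and the acid-bearing ring stay the same.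

Among the measured compounds shown here, no measured step shows the effect of swapping one group for another on this ring, so the size of the step from compound 3 to compound 4 is not pinned down by the data. With a smaller group in place of the cyanomethoxy, the step is expected to be modest, most likely a slight shift toward a higher number, within or only just beyond the scatter, so that a 1.6-fold higher number from compound 3 to compound 4 (0.21 log units; within the scatter) is the expected change. Compound 4 is therefore estimated to give about 1100 nM in this assay, with a plausible range from 350 nM to 3500 nM.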

Compound 4, half-maximal inhibitory concentration: 343 nM
Beside the measured number, compound 4's estimate is 3.2-fold (0.51 log units) above it; the whole stated range lies above it.
By their numbers in this assay, from the lowest: compounds 4 and 3 (each within the scatter of the next); then compound 1. At a limit, above all of these: compound 2.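

Among the compounds shown here, the step of a 2.0-fold lower number from compound 3 to compound 4 (0.30 log units; within the scatter) in this assay gives the first direct reading at this aromatic carbon, which the earlier compounds, differing from one another in more than one place, could not provide. Cyanomethoxy, with its triple bond and hydrogen-bond acceptors, and methyl, with no acceptor, cannot be told apart here, so neither the larger group nor its acceptors are needed to keep a value in this range. None of the information at hand explains this step.

With only these two groups at this place, the data do not show how an amine, a carboxylic acid or a longer chain would read there. Going by these compounds, whether a plain hydrogen on this carbon would give a similar value also remains open.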